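This account rests on a few compounds, and the source may have more. Where it says the series, first, only, none or still open, it means among the compounds named here.

Measured so far in a functional assay on DU-145 cells (Homo sapiens) for inhibition, read by CCK-8 assay, with a stated time of 72 h; a lower number here means a stronger inhibitor, a higher number a weaker inhibitor:
Compound 1 (`O=C(/C=C/c1cccnc1)NCCCCCc1ccc(S(=O)(=O)Nc2ccccc2)cc1`) gives (581 nM)
Compound 2 (`Cc1cccc(NS(=O)(=O)c2cccc(CCCCCCNC(=O)/C=C/c3cccnc3)c2)c1`) gives (41.7 nM)

Compound 2 holds the lower of the two numbers, and its gap to compound 1 lies beyond the scatter. Compound 3 (`O=C(/C=C/c1cccnc1)NCCCCCCc1cccc(S(=O)(=O)Nc2ccc(F)cc2)c1`) has not yet been measured. It departs from compound 2 at one place (4-fluorophenyl in place of 3-methylphenyl on a sulfonamide nitrogen) with 4-fluorophenyl in place of 3-methylphenyl on a sulfonamide nitrogen. Among the measured compounds shown here, no measured pair differs in one place, so the data offer no direct guide to this swap. The expectation therefore starts from compound 2 (41.7 nM) and stays near it. In this assay a small move toward a higher number is expected, possibly within the scatter, and the estimated step (a 1.4-fold higher number from compound 2 to compound 3 (0.16 log units; within the scatter)) is correspondingly modest. For compound 3 the estimate is (60 nM) with an expected range from 20 nM to 200 nM in this measurement.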

Compound 3, half-maximal inhibitory concentration: 10.6 nM
Compound 3: middle estimate off by 5.7-fold (0.75 log units), on the high side; measured number below the stated range.
By their numbers in this assay, from the lowest: compound 3; then compound 2; then compound 1.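

In this assay, the group on the sulfonamide nitrogen can shift the number on its own: with the rest of the structure unchanged, 4-fluorophenyl in place of 3-methylphenyl gives a 3.9-fold lower number from compound 2 to compound 3 (0.59 log units; beyond the scatter). Among the compounds shown here, this is the first comparison in the set that isolates a single place, so it shows that this position is sensitive to substitution and that this swap moves toward a stronger inhibitor. No measurement shown explains the step.

The compounds shown leave open whether the step belongs to the arrival of the fluorine or to the departure of the methyl, and how a chlorine, a methoxy group or an amine on that ring would read in this assay. Also open, from the compounds shown here alone, is how a longer chain would behave alongside the 4-fluorophenyl group.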